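The source may report more compounds than this note shows. Statements on the series, on what has been measured and on what is new or still open speak of the compounds shown alone.

Measured so far in a toxicity assay on THP-1 cells (Homo sapiens) for inhibition; on this read-out higher numbers stand for lower toxicity in this test and lower numbers for higher toxicity in this test:
compound 1 `CCC(=O)Nc1ncc(-c2ccc(OC)cc2)n1C` gives > 100000 nM.
compound 2 `O=C(Nc1ncc(-c2ccccc2)o1)c1ccc(F)cc1` gives 17000 nM.
compound 3 `Cn1c(-c2cccc(Br)c2)cnc1NC(=O)c1ccc(F)cc1` gives > 50000 nM.

Compound 1 shows in this assay a limit of the assay, not a number (the limit of > 100000 nM in this assay, at which 1 of the 3 values shown sits). Compound 3 likewise gives only a limit (the limit of > 50000 nM in this assay, at which 1 of the 3 values shown sits). Compound 2 alone gives an actual number. Going by the values given here, no two measured compounds differ in one place, so no measured step is available in this assay. Compound 4 `COc1ccc(-c2cnc(NC(=O)C3CCCCC3)n2C)cc1` differs from compound 1 by cyclohexyl in place of ethyl on a carbonyl carbon. With nothing measured on this kind of change, the expected step of an at least 1.4-fold lower number from compound 1 to compound 4 (0.15 log units; that floor lies within the scatter) is modest, toward somewhat higher toxicity, and may well stay within the usual scatter. The estimate for compound 4 in this assay is 70000 nM, ranging from 15000 nM to 200000 nM, with a fair chance that only a limit is reported.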

Compound 4, half-maximal cytotoxic concentration: > 100000 nM
Compound 4 ended at the assay's limit; the forecaster's own chance of this, stated with the estimate: 50%; middle value at least 1.4-fold (0.15 log units) away from the limit.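

In this assay compound 4 gives > 100000 nM, a limit and not a number. Compound 1 gives the same limit, > 100000 nM, so the step to compound 4 cannot be read. On these data alone, how far cyclohexyl in place of ethyl on a carbonyl carbon moves the values in this assay stays open.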